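The compounds below may be only part of what the source reports. "The series", "measured", "known", "first", "only" and "open" are said of these compounds alone.

Working notes on the dichloroacetanilide series. Compound 1 `O=C(Nc1ccccc1)C(Cl)Cl` carries the bare phenyl ring, and in a functional assay on KB cells (Homo sapiens) for antiproliferative activity, read by MTT assay, with a stated time of 72 h (a higher number here means a weaker inhibitor, a lower number a stronger inhibitor), compound 1 gives "not determined" (no result reported), so no result is reported for it. For the measured compounds named here, compound 2 `O=C(Nc1ccc(Br)cc1)C(Cl)Cl` is the only member with a number: in this assay compound 2 gives 21700 nM. Since compound 1 has no value, compound 2 stands alone, with nothing to rank it against.

Compound 3 `O=C(Nc1ccc(I)cc1)C(Cl)Cl` is the next member to be measured. Compared with compound 2, the change is iodo in place of bromo on an aromatic carbon. Going by the values given here, no step between measured compounds is available to calibrate this exchange. The expectation is a step for a 1.4-fold lower number from compound 2 to compound 3 (0.16 log units; within the scatter) that stays within or only just beyond the usual scatter, if anything toward a slightly lower number. Compound 3 is therefore estimated at 15000 nM in this assay, with a range from 5000 nM to 45000 nM.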

Compound 3, half-maximal inhibitory concentration: 66200 nM
Estimate against measurement, compound 3: 4.4-fold (0.64 log units) below, outside the stated range (above it).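

This position is now shown to respond to the identity of the halogen: in this assay, iodo in place of bromo, para to a group of 6 heavy atoms, gives a 3.1-fold higher number from compound 2 to compound 3 (0.48 log units; beyond the scatter). The step fixes a direction for this one pair only, and two values establish no trend across the halogens. Nothing available bears on why the exchange moves the number this way.

Compound 1 provides no number, so neither halogen can be compared with the bare phenyl ring of the series. Also open, going by these compounds, is how a fluoro, chloro, methoxy, amine or carboxylic acid at this same position would compare with bromo and iodo in this assay.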